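This account rests on a few compounds, and the source may have more. Where it says the series, first, only, none or still open, it means among the compounds named here.

Measured compounds:
- compound 1, `CCC(=O)N[C@@H]1CCCc2c1cncc2N1CCc2cc(Cl)ccc2C1=O`: 3330 nM
- compound 2, `CS(=O)(=O)N[C@@H]1CCCc2c1cncc2N1Cc2cc(Cl)ccc2C1=O`: 9350 nM
- compound 3, `CC(=O)N[C@H]1CCCc2c1cncc2N1Cc2cc(Cl)ccc2C1=O`: 39600 nM

Of the compounds shown here, three built on a shared core have been tested in an ADME assay on cells for inhibition of cytochrome P450 11B1, mitochondrial (Homo sapiens), read by HTRF; a lower number here means a stronger inhibitor, a higher number a weaker inhibitor. Compound 1 gives 3330 nM, the lowest number of the three. Compound 2 gives 9350 nM, a higher number that lies beyond the usual scatter of the measurement, and compound 3 gives 39600 nM, the highest of the set and again clearly separated from compound 1. Of these three, then, compound 1 is the strongest inhibitor.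

The next compound, compound 4, `CC(=O)N[C@@H]1CCCc2c1cncc2N1CCc2cc(Cl)ccc2C1=O`, has not yet been measured in this assay. It is made from compound 1 by a single small change: hydrogen in place of methyl on a saturated chain carbon bound to a carbonyl carbon. The amide that carries the propanoyl group in compound 1 becomes an acetamido group in compound 4; no other part of the structure moves.

Among the compounds with values here, no pair of the measured compounds shows this change on its own, so there is no measured step to lean on. For a loss of one carbon from a short chain like this, a small shift is expected, most likely toward a somewhat higher number, and possibly no change beyond the scatter. The expected step from compound 1 to compound 4 is a 1.5-fold higher number from compound 1 to compound 4 (0.18 log units; within the scatter). Compound 4 is therefore estimated at 5000 nM, with a plausible range from 2000 nM to 12000 nM.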

Compound 4, half-maximal inhibitory concentration: 3920 nM
The estimate for compound 4 lay 1.3-fold (0.11 log units) above the measured number, within the range that was stated.
By their numbers in this assay, from the lowest: compounds 1 and 4 (each within the scatter of the next); then compound 2; then compound 3.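

In this assay, going from propanoylamino to acetamido gives a 1.2-fold higher number from compound 1 to compound 4 (0.07 log units; within the scatter), so swapping this methyl for hydrogen on the saturated chain carbon bound to the carbonyl carbon leaves a difference that cannot be told apart from repeat-measurement noise. Within the data shown here, this is the first direct reading of a single change in the set, since no earlier pair of measured compounds differed in only one place; it shows that, in this assay, shortening ethyl to methyl at this position does not separate compound 1 from compound 4. No measurement on hand offers a reason for this flat result.

As far as these compounds go, the pair covers only two short chains, so it remains open whether a longer chain such as butanoyl, a branched chain such as isobutyryl, or a chain ending in an amine or a carboxylic acid would move the number beyond the scatter. Also open, from the compounds shown here alone, is what a formyl group or a bare amine in place of the whole acyl group would do on the core of compound 1.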